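Series of benzyl-triazolyl aryl ethers in PANC-1 growth inhibition

This account rests on a few compounds, and the source may have more. Where it says the series, first, only, none or still open, it means among the compounds named here.

Measured compounds:
compound 1, `Clc1ccc(Cn2cc(COc3ccc(Cl)cc3)nn2)cc1`, > 100 ug/mL
compound 2, `Clc1ccc(OCc2cn(Cc3ccc(Br)cc3)nn2)cc1`, > 100 ug/mL
compound 3, `Clc1ccc(Cn2cc(COc3c(Cl)cc(Cl)cc3Cl)nn2)cc1`, > 100 ug/mL

In an ADME assay on PANC-1 cells (Homo sapiens) for inhibition, read by MTT assay, with a stated time of 48 h (on this read-out higher numbers stand for weaker inhibition of growth and lower numbers for stronger inhibition of growth), compound 1 returns a limit of the assay, > 100 ug/mL, not a number. Compound 2 in this assay likewise returns only the limit > 100 ug/mL. Compound 3 sits at the same limit in this assay with > 100 ug/mL. All three values are limits, so no value can be placed against another; the evidence is simply (the limit of > 100 ug/mL in this assay, at which 3 of the 3 values shown sit).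

The change from compound 1 to compound 2 is bromo in place of chloro on an aromatic carbon. Its step, a step that the two limits leave unreadable from compound 1 to compound 2, cannot be read, both ends being limits. The difference between the core of compound 1 and the core of compound 3 is not broken down here.

Compound 4, `Clc1cc(Cl)c(OCc2cn(Cc3ccc(Br)cc3)nn2)c(Cl)c1`, is not yet measured. It differs from compound 3 by bromo in place of chloro on an aromatic carbon, the same change as that from compound 1 to compound 2. Since compound 3 gives only the limit > 100 ug/mL, and since the matching change from compound 1 to compound 2 left both compounds at the limit, compound 4 is expected to stay at the limit too, with the step that the limit leaves unreadable from compound 3 to compound 4 being an expectation rather than a readable size. For compound 4 in this assay an estimated value of 150 ug/mL is expected, with a range from 70 ug/mL to 400 ug/mL, and most likely a limit rather than a number.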

Compound 4, concentration for 50% growth inhibition: > 100 ug/mL
Compound 4: only a limit was reported; the forecaster's own chance of this, stated with the estimate: 85%; the middle value lies beyond the limit too.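

Compound 3 and compound 4 each return a limit rather than a number in this assay, so no new step can be read from this pair: the limit of > 100 ug/mL in this assay, at which 4 of the 4 values shown sit.

The compounds shown leave open how strongly any of them inhibits growth, and whether bromo in place of chloro on an aromatic carbon has any readable effect on the shared core or on the core of compound 3.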